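The source may hold more compounds than are shown below. What is called first, only, known or untested is meant among the compounds shown, and "the series" means these compounds.

Compound 1 `Cc1nc(C(NC(=O)C(=O)Nc2ccc(Cl)c(F)c2)C2CCCCN2)sc1CO` was tested in an ADME assay on MT2 cells (Homo sapiens) for cytotoxicity, read by XTT assay, with a stated time of 4 days (a higher number here means that more compound is tolerated, a lower number that less compound is tolerated), where compound 1 gives 77800 nM. Compound 2 `Cc1nc(C(NC(=O)C(=O)Nc2ccc(Cl)c(F)c2)C2CCCCN2)sc1CCO` differs from compound 1 by hydroxymethyl in place of hydroxy on a saturated chain carbon bound to an aromatic carbon. For compound 2 this assay reports only a limit, > 41000 nM, and not a number. The step that the limit leaves unreadable from compound 1 to compound 2 therefore has no readable size because of the limit of > 41000 nM in this assay, at which 1 of the 3 values shown sits. Compound 3 `Cc1nc(C(NC(=O)C(=O)Nc2ccc(F)cc2)C2CCCCN2)sc1CO` carries a different core from compound 1, the difference being (4-fluorophenyl in place of 4-chloro-3-fluorophenyl on an amide-type nitrogen). For compound 3 this assay again reports only a limit, > 113000 nM. The step of an at least 1.4-fold higher number from compound 1 to compound 3 (0.16 log units; that floor lies within the scatter) is known only as a floor because of the limit of > 113000 nM in this assay, at which 1 of the 3 values shown sits, and that floor lies within the usual scatter.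

Compound 4 `Cc1nc(C(NC(=O)C(=O)Nc2ccc(F)cc2)C2CCCCN2)sc1CCO` has not yet been measured. It differs from compound 3 by hydroxymethyl in place of hydroxy on a saturated chain carbon bound to an aromatic carbon, the same change, at the same place, as the one whose size reads a step that the limit leaves unreadable from compound 1 to compound 2. That earlier step gives no readable size, so the expectation for compound 4 rests mainly on where its neighbours sit. Compound 3 reaches only a limit, > 113000 nM. Compound 2, which carries the hydroxymethyl group, likewise reaches only a limit, > 41000 nM. The expected step is an at least 1.1-fold lower number from compound 3 to compound 4 (0.05 log units; that floor lies within the scatter), meaning that compound 4 is expected to stay in the same weakly cytotoxic region as its neighbours, and that this assay may well report only a limit for it too. Compound 4 is thus estimated at about 100000 nM, with a likely range from 40000 nM to 250000 nM.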

Compound 4, half-maximal cytotoxic concentration: 109000 nM
The estimate for compound 4 lay 1.1-fold (0.04 log units) below the measured number, within the range that was stated.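

On the core of compound 3, replacing hydroxymethyl with 2-hydroxyethyl gives an at least 1.0-fold lower number from compound 3 to compound 4 (0.01 log units; that floor lies within the scatter) in this assay. This step is only a floor, and its true size remains unknown because compound 3 reaches only a limit: the limit of > 113000 nM in this assay, at which 1 of the 4 values shown sits. The same change on the core of compound 1 and the step from compound 2 to compound 4 cannot be read, so the data do not show whether the change has the same effect on both cores, because compound 2 also reaches only a limit: the limit of > 41000 nM in this assay, at which 1 of the 4 values shown sits.

The compounds shown leave open what would happen at this place with an amine, a carboxylic acid or a longer chain ending in hydroxy in place of hydroxymethyl or 2-hydroxyethyl. Comparing the two cores would take a true number for both compound 2 and compound 3, since a pair of steps can only be set side by side once each has a readable size.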